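This account rests on a few compounds, and the source may have more. Where it says the series, first, only, none or still open, it means among the compounds named here.

Working notes on the series. Compound 1 `COc1ccc(-c2cn3cc(C4=CCN(C(=O)c5ccc(Cl)cc5)CC4)ccc3n2)cc1OC` and compound 2 `COc1ccc(-c2cn3cc(C4=CCN(S(=O)(=O)C5CCCCC5)CC4)ccc3n2)cc1OC` share one core and differ only at the amine nitrogen in the ring. In a functional assay on A549 cells (Homo sapiens) for antiproliferative activity, read by MTT assay, with a stated time of 48 h (on this read-out higher numbers stand for weaker inhibition and lower numbers for stronger inhibition), compound 1 gives 8970 nM; in this assay compound 2 gives 4490 nM. Going by the values given here, the only measured step, a 2.0-fold lower number from compound 1 to compound 2 (0.30 log units; within the scatter), is within the scatter, so compound 2 has the lowest of the two numbers but cannot be said to differ from compound 1 on this read-out.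

Compound 3 `COc1ccc(-c2cn3cc(C4=CCN(S(=O)(=O)c5ccccc5)CC4)ccc3n2)cc1OC` is not yet measured. It differs from compound 2 by phenyl in place of cyclohexyl on a sulfonyl sulfur. Among the compounds with values here, no measured step swaps a ring on a sulfonyl sulfur; the step from compound 1 to compound 2 changed both the linking group and the ring at once and stayed within the scatter, which is the only guidance available. On that basis, in this assay a step of a 1.0-fold higher number from compound 2 to compound 3 (0.00 log units; within the scatter) is expected, meaning no change beyond the scatter in either direction. For compound 3 the value in this assay is estimated at 4500 nM, with a range from 1800 nM to 11000 nM.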

Compound 3, half-maximal inhibitory concentration: 7660 nM
For compound 3 the middle estimate is 1.7-fold (0.23 log units) below the measured one; the range from low to high includes it.
By their numbers in this assay, from the lowest: compounds 2, 3 and 1 (each within the scatter of the next).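

In this assay, the first swap made on the ring carried by the sulfonyl sulfur gives a 1.7-fold higher number from compound 2 to compound 3 (0.23 log units; within the scatter), so at this place phenyl and cyclohexyl cannot be told apart on this read-out, whether the ring is aromatic or not. The step that exchanges the linking group while keeping an aromatic ring on it gives a 1.2-fold lower number from compound 1 to compound 3 (0.07 log units; within the scatter), so phenylsulfonyl and (4-chlorophenyl)carbonyl on the amine nitrogen in the ring cannot be told apart either, and the three groups now seen at this nitrogen leave the series flat within the scatter. No measurement of any property of these groups bears on these steps, and the data offer no explanation for them.

As far as these compounds go, all three compounds carry a six-membered carbon ring on the linking group, so it remains open whether an amine, a carboxylic acid or a longer chain on the sulfonyl sulfur would give a step beyond the scatter. The shared core is the same throughout, which leaves open how much of the read-out depends on it rather than on the group at the nitrogen.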